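The source may hold more compounds than are shown below. What is called first, only, known or untested is meant among the compounds shown, and "the series" means these compounds.

Measured so far in a physicochemical assay for lipophilicity, read by HPLC, measured as octanol-water partition (on this read-out higher numbers stand for higher lipophilicity and lower numbers for lower lipophilicity), are three compounds:

- compound 1 `O=C(CSc1ncnc2c1cnn2-c1ccccc1Cl)Nc1ccccc1` gives 4.3
- compound 2 `Cn1ccc(NC(=O)CSc2ncnc3c2cnn3-c2ccccc2Cl)n1` gives 2.5
- compound 3 `CCCCC(Sc1ncnc2c1cnn2-c1ccccc1Cl)C(=O)Nc1nc(C)cs1` gives 6.4

Compound 3 stands highest of the three, at 6.4 on this scale, with both others beyond the scatter below it. Compound 4 `COCCC(Sc1ncnc2c1cnn2-c1ccccc1Cl)C(=O)Nc1nc(C)cs1` has not yet been measured. Among the measured compounds shown here, its single change from compound 3 is this: methoxy in place of ethyl on a saturated chain carbon, three bonds along the chain from a carbonyl carbon and a sulfur. Cut one bond further out, the same change reads butyl to 2-methoxyethyl.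

For the measured compounds named here, only one measured step is available, a number 1.80 log units lower from compound 1 to compound 2 (beyond the scatter), and it is large. It sits at a different place and exchanges one ring for another, so it is only a loose guide. A downward step of moderate size is expected in this assay, smaller than that one but still beyond the scatter. The expected change is a number 1.20 log units lower from compound 3 to compound 4 (beyond the scatter) on this scale. The estimate for compound 4 is 5.2, with an expected range of 4.6 to 5.8 until a measurement is made.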

Compound 4, distribution coefficient: 4.8
Compound 4: the middle estimate sits 0.40 log units above what was measured; low and high end bracket the measured number.
By their numbers in this assay, from the lowest: compound 2; then compound 1; then compound 4; then compound 3.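

Putting methoxy in place of ethyl on this saturated chain carbon leaves the heavy-atom count unchanged and replaces one carbon with one oxygen, yet in this assay it gives a number 1.60 log units lower from compound 3 to compound 4 (beyond the scatter), a large step beyond the scatter. The earlier compounds shown here showed a large step only for one ring exchanged for another on an amide-type nitrogen, whereas this result shows that a large step can also arise on the chain, with no ring involved. Nothing available here explains the size of this step.

With only butyl and 2-methoxyethyl shown at this position, it remains open how an amine, a carboxylic acid or a longer chain carrying the methoxy would read. On these data alone, it also remains open whether the same exchange would give a step of similar size on other compounds in this set.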